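A few compounds are considered here, and "the series" means these few. Any claim that something is new, unique, unknown or untested is made for them only; others in the source may bear on it.

Measured so far in a functional assay on PC-3 cells (Homo sapiens) for inhibition; a higher number here means a weaker inhibitor, a lower number a stronger inhibitor:

Compound 1, `COc1cc2nc(N3CCN(S(=O)(=O)c4ccc(I)cc4)CC3)nc(N)c2cc1OC`: 15000 nM
Compound 2, `COc1cc2nc(N3CCN(S(=O)(=O)c4ccc(Cl)s4)CC3)nc(N)c2cc1OC`: 25000 nM
Compound 3, `COc1ccc(S(=O)(=O)N2CCN(c3nc(N)c4cc(OC)c(OC)cc4n3)CC2)cc1`: 39000 nM

Compound 3 carries the highest number of the three, so it is the weakest inhibitor in this set. Its gap to compound 2 lies within the scatter, as a 1.6-fold higher number from compound 2 to compound 3 (0.19 log units; within the scatter) shows, while its gap to compound 1, given by a 2.6-fold higher number from compound 1 to compound 3 (0.41 log units; beyond the scatter), is modest but beyond the scatter. The whole set, in fact, moves within a narrow band; a 1.7-fold higher number from compound 1 to compound 2 (0.22 log units; within the scatter) is also within the scatter.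

Compound 4, `COc1cc2nc(N3CCN(S(=O)(=O)c4ccc(OC(F)(F)F)cc4)CC3)nc(N)c2cc1OC`, differs from compound 3 by trifluoromethyl in place of methyl on an oxygen on an aromatic ring, that is, methoxy becomes trifluoromethoxy on the ring attached to the sulfonyl sulfur. Going by the values given here, no measured step makes exactly this change. The nearest comparison is the step from iodo to methoxy on that ring, a 2.6-fold higher number from compound 1 to compound 3 (0.41 log units; beyond the scatter), and the ring swaps in the other two steps, all of which moved the number only a little. Among the compounds with values here, a small step, if any, is therefore expected, and probably toward a lower number, since the only change beyond the scatter ran the other way when methoxy replaced a halogen. The expected step is a 1.6-fold lower number from compound 3 to compound 4 (0.19 log units; within the scatter).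

Compound 4 is estimated at 25000 nM, within a range from 10000 nM to 60000 nM.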

Compound 4, half-maximal inhibitory concentration: 25000 nM
Estimate against measurement, compound 4: no gap at the digits printed; the range from low to high includes it.
By their numbers in this assay, from the lowest: compounds 1, 2, 4 and 3 (each within the scatter of the next, the first and the last beyond it).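

Measured in this assay the change from methoxy to trifluoromethoxy, which puts trifluoromethyl in place of methyl on the oxygen, gives a step that stays within the scatter (a 1.6-fold lower number from compound 3 to compound 4 (0.19 log units; within the scatter)). The new group also stays within the scatter of the two other groups it can be set against: 5-chlorothiophen-2-yl on the sulfonyl sulfur (no change at the digits printed from compound 2 to compound 4 (within the scatter)) and iodo on the aromatic carbon (a 1.7-fold higher number from compound 1 to compound 4 (0.22 log units; within the scatter)). So a fourth group on the sulfonyl sulfur joins the same narrow band, the one step beyond the scatter among these four compounds still being the modest one from iodo to methoxy (a 2.6-fold higher number from compound 1 to compound 3 (0.41 log units; beyond the scatter)), and nothing given here explains why these groups sit so close together.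

What the compounds shown leave open is whether any group on this aromatic ring can move the number far outside this band, for example an amine, a carboxylic acid or a longer alkyl chain. They also leave open whether the sulfonyl sulfur itself matters, something a carbonyl in its place could test.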